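The source may hold more compounds than are shown below. What is called first, only, known or untested is meant among the compounds shown, and "the series" means these compounds.

Compound 1 `CN(C(=O)C(C)(C)C)c1ccc2[nH]c(-c3n[nH]c4ccccc34)cc2n1`: 24400 nM
Compound 2 `CN(C(=O)c1ccccc1)c1ccc2[nH]c(-c3n[nH]c4ccccc34)cc2n1`: 13800 nM
Compound 3 `CN(c1ccc2[nH]c(-c3n[nH]c4ccccc34)cc2n1)S(=O)(=O)c1ccc(Br)cc1`: 19700 nM

Of the compounds shown here, three built on one shared core have so far been measured in a functional assay on A549 cells (Homo sapiens) for antiproliferative activity, read by MTT assay, with a stated time of 72 h; on this read-out higher numbers stand for weaker inhibition and lower numbers for stronger inhibition. Compound 3 carries the second highest of the three numbers, but this position says little: the step of a 1.2-fold lower number from compound 1 to compound 3 (0.09 log units; within the scatter) and the step of a 1.4-fold higher number from compound 2 to compound 3 (0.15 log units; within the scatter) both lie within the scatter, so no order among the three can be drawn from these values.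

Compound 4 `COc1ccc(S(=O)(=O)N(C)c2ccc3[nH]c(-c4n[nH]c5ccccc45)cc3n2)c(OC)c1` is the next compound to be tested. It differs from compound 3 in one place: 2,4-dimethoxyphenyl in place of 4-bromophenyl on a sulfonyl sulfur. For the measured compounds named here, none of the measured steps touches this part of the molecule. The steps of a 1.8-fold lower number from compound 1 to compound 2 (0.25 log units; within the scatter) and a 1.4-fold higher number from compound 2 to compound 3 (0.15 log units; within the scatter) exchange the whole group on the nitrogen, and the step of a 1.2-fold lower number from compound 1 to compound 3 (0.09 log units; within the scatter) does the same; each of them stays within the scatter. Going by the values given here, the data hold no example of a changed substituent on the aryl ring of the sulfonyl, so there is nothing to suggest a move in either direction.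

The expected step for compound 4 is therefore none beyond the scatter, a 1.1-fold lower number from compound 3 to compound 4 (0.04 log units; within the scatter). Compound 4 is estimated at 18000 nM, with a range from 6000 nM to 50000 nM.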

Compound 4, half-maximal inhibitory concentration: 25900 nM
Compound 4: middle estimate off by 1.4-fold (0.16 log units), on the low side; the measured number falls inside the stated range.
By their numbers in this assay, from the lowest: compounds 2, 3, 1 and 4 (each within the scatter of the next).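

In this assay, replacing 4-bromophenyl with 2,4-dimethoxyphenyl on the sulfonyl sulfur gives a 1.3-fold higher number from compound 3 to compound 4 (0.12 log units; within the scatter). The earlier steps shown here exchanged the whole group on the nitrogen, whereas this one keeps the sulfonyl and its aromatic ring and alters only what that ring carries; the entering group has 10 heavy atoms and 2 hydrogen-bond acceptors, against 7 and 0 for the leaving group, yet no change can be read from the result. So at this position, this particular exchange does not shift antiproliferative activity measurably, and no measurement offered here explains why.

Because the bromine is lost and both methoxy groups arrive in a single step, the compounds shown cannot say what each of these changes does alone, and a phenyl ring with one methoxy group would be needed to begin separating them. Going by these compounds, it also remains open whether an amine or a carboxylic acid on that ring, or a simple alkyl chain on the sulfonyl sulfur in place of the ring, would move the number beyond the scatter.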